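Iodo in place of thiophen-2-yl: expecting compound 3

This account rests on a few compounds, and the source may have more. Where it says the series, first, only, none or still open, it means among the compounds named here.

Compound 1 `Cc1nc(N)c2c(-c3cccs3)cn([C@@H]3O[C@H](CO)[C@@H](O)[C@H]3O)c2n1` stands only at a limit on the numbers shown. In an ADME assay on BJ cells (Homo sapiens), read by MTT assay, with a stated time of 72 h (on this read-out lower numbers stand for stronger inhibition and higher numbers for weaker inhibition), compound 1 gives > 100000 nM, a limit of the measurement and not a number. Compound 2 `C#Cc1cn([C@@H]2O[C@H](CO)[C@@H](O)[C@H]2O)c2nc(N)nc(OC)c12` in this assay gives > 100000 nM, again a limit. Among the compounds with values here, the only evidence across the set is the limit of > 100000 nM in this assay, at which 2 of the 2 values shown sit. Compound 3 `Cc1nc(N)c2c(I)cn([C@@H]3O[C@H](CO)[C@@H](O)[C@H]3O)c2n1` differs from compound 1 in one place (iodo in place of thiophen-2-yl on an aromatic carbon). Within the data shown here, no measured step covers this change, so compound 3 is expected to show a number no higher from compound 1 to compound 3 (the limit leaves the size open), no step beyond the scatter. Compound 3 is estimated to give 100000 nM in this assay, within 30000 nM to 300000 nM.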

Compound 3, half-maximal inhibitory concentration: 24600 nM
Compound 3: middle estimate off by 4.1-fold (0.61 log units), on the high side, outside the stated range (below it).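

Iodo in place of thiophen-2-yl on this aromatic carbon gives an at least 4.0-fold lower number from compound 1 to compound 3 (0.60 log units; beyond the scatter) in this assay. Within the data shown here, the position can therefore move the read-out off the limit, which the earlier compounds could not show. Compound 3 is the only compound shown that gives a number rather than a limit: the limit of > 100000 nM in this assay, at which 2 of the 3 values shown sit.

The limit on compound 1 leaves the full size of the step open. On these data alone, it also remains open whether iodo itself or the loss of the thiophen-2-yl ring matters, and how a phenyl ring, an amine or a methyl group on this carbon would read.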